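Amide side chains: the step from compound 3 to compound 4

This account rests on a few compounds, and the source may have more. Where it says the series, first, only, none or still open, it means among the compounds named here.

In a functional assay on BXPC-3 cells (Homo sapiens) for antiproliferative activity, read by MTT assay, with a stated time of 24 h (on this read-out lower numbers stand for stronger inhibition and higher numbers for weaker inhibition), compound 1 `CCn1c(C(=O)NCC(=O)OC)ccc1C(CC)(CC)c1ccc(OCS(=O)(=O)c2ccccc2)c(C)c1` gives 20000 nM. Compound 2 `CCn1c(C(=O)NCCC(=O)OC)ccc1C(CC)(CC)c1ccc(OCS(=O)(=O)c2ccccc2)c(C)c1` gives > 50000 nM, which is a limit of the assay. Compound 3 `CCn1c(C(=O)NC2(CO)CC2)ccc1C(CC)(CC)c1ccc(OCS(=O)(=O)c2ccccc2)c(C)c1` gives 45400 nM, the higher of the two actual numbers in the set, and its nearest neighbour among them is compound 1, with a 2.3-fold higher number from compound 1 to compound 3 (0.36 log units; beyond the scatter).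

Compound 4 `CCn1c(C(=O)N[C@@H](CO)CCO)ccc1C(CC)(CC)c1ccc(OCS(=O)(=O)c2ccccc2)c(C)c1` carries a new group on the amide-type nitrogen: 3-hydroxy-1-(hydroxymethyl)propyl in place of 1-(hydroxymethyl)cyclopropyl on an amide-type nitrogen. Within the data shown here, no measured step makes this exact exchange. Among the measured compounds shown here, the steps that bear on it are changes at the same nitrogen. Compound 3 is reached with a 2.3-fold higher number from compound 1 to compound 3 (0.36 log units; beyond the scatter), and compound 2 with an at least 2.5-fold higher number from compound 1 to compound 2 (0.39 log units; beyond the scatter), both modest. The remaining step is an at least 1.1-fold lower number from compound 2 to compound 3 (0.04 log units; that floor lies within the scatter), whose floor lies within the scatter.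

Steps at this nitrogen have therefore stayed modest, so no step beyond the scatter is expected in this assay. The estimated step is a 1.5-fold lower number from compound 3 to compound 4 (0.18 log units; within the scatter). For compound 4 the expected value is 30000 nM, with an estimated range of 12000 nM to 50000 nM.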

Compound 4, half-maximal inhibitory concentration: > 50000 nM
Compound 4 was reported as a limit (the forecaster's own chance of this, stated with the estimate: 30%); middle value at least 1.6-fold (0.22 log units) away from the limit.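

In this assay compound 4 gives > 50000 nM, which is a limit of the assay. Exchanging 1-(hydroxymethyl)cyclopropyl for the ring-free 3-hydroxy-1-(hydroxymethyl)propyl on the amide-type nitrogen gives an at least 1.1-fold higher number from compound 3 to compound 4 (0.04 log units; that floor lies within the scatter), so no gain appears, although the floor of this step does not separate the two groups. Set against (methoxycarbonyl)methyl, the same group gives an at least 2.5-fold higher number from compound 1 to compound 4 (0.39 log units; beyond the scatter), so the second hydroxy group brings no return towards the lowest number in the set.

From the compounds shown here alone, the step between compound 2 and compound 4 cannot be read, and the order of these two compounds stays unknown: the limit of > 50000 nM in this assay, at which 2 of the 4 values shown sit. Whether an amine or a carboxylic acid in the side chain on this nitrogen would bring the number below that of compound 1 remains open.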